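The compounds below may be only part of what the source reports. "The series", "measured", "known", "first", "only" and "open" are said of these compounds alone.

Compound 1, `CC(C)c1n[nH]c2c(NCc3ccc(-c4ccccn4)cc3)nc(SCCC(N)=O)nc12`, gives 120 nM.
Compound 2, `CC(C)c1n[nH]c2c(NCc3ccc(-c4ccccn4)cc3)nc(SCCNC(=N)N)nc12`, gives 390 nM.
Compound 3, `CC(C)c1n[nH]c2c(NCc3ccc(-c4ccccn4)cc3)nc(SCC(O)CO)nc12`, gives 21 nM.

These three compounds share one core and differ only in the group carried on the chain attached to the sulfur. In a functional assay on HT cells (Homo sapiens) for antiproliferative activity, read by fluorescence, with a stated time of 72 h (on this read-out lower numbers stand for stronger inhibition of growth and higher numbers for weaker inhibition of growth), compound 2 stands highest of the three numbers, that is, it is the weakest grower-inhibitor among them: the step of a 3.3-fold higher number from compound 1 to compound 2 (0.51 log units; beyond the scatter) and the step of a 19-fold lower number from compound 2 to compound 3 (1.27 log units; beyond the scatter) both place it above its neighbours, and both steps lie beyond the usual scatter.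

Compound 4, `CC(C)c1n[nH]c2c(NCc3ccc(-c4ccccn4)cc3)nc(SCCCO)nc12`, has not yet been measured. It differs from compound 2 by a group of 2 heavy atoms (1 carbon, 1 oxygen; no ring) in place of a group of 4 heavy atoms (1 carbon, 3 nitrogen; no ring), on a saturated chain carbon, two bonds along the chain from a sulfur. For the measured compounds named here, two measured steps bear on this change. The first is a 19-fold lower number from compound 2 to compound 3 (1.27 log units; beyond the scatter), where a group built of carbon and oxygen replaced a nitrogen-rich group on the same chain. The second is a 3.3-fold higher number from compound 1 to compound 2 (0.51 log units; beyond the scatter), read in reverse, where removing the nitrogen-rich group brought a lower number. Both point the same way, so a lower number is expected for compound 4 than for compound 2, though not necessarily as far down as compound 3 reached.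

The step expected from this change is a 7.1-fold lower number from compound 2 to compound 4 (0.85 log units; beyond the scatter). Compound 4 is therefore estimated at 55 nM, with a likely range from 20 nM to 150 nM.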

Compound 4, concentration for 50% growth inhibition: 109 nM
Compound 4: the middle estimate sits 2.0-fold (0.30 log units) below what was measured; the range from low to high includes it.
By their numbers in this assay, from the lowest: compound 3; then compounds 4 and 1 (each within the scatter of the next); then compound 2.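

In this assay, putting hydroxymethyl in place of the nitrogen-rich end group recovers only part of the distance between compound 2 and compound 3, with a 3.6-fold lower number from compound 2 to compound 4 (0.55 log units; beyond the scatter) against the larger drop to the diol. Much of the remainder rests on a single hydroxy: hydrogen in its place, on a saturated chain carbon bound to two saturated chain carbons, gives a 5.2-fold higher number from compound 3 to compound 4 (0.72 log units; beyond the scatter), so this small edit matters at this position. Hydroxymethyl and carbamoyl, by contrast, cannot be told apart here, with a 1.1-fold lower number from compound 1 to compound 4 (0.04 log units; within the scatter), which means that these two different chain ends, two bonds along the chain from a sulfur, give the same result on this read-out.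

No measurement here gives a reason why that one hydroxy counts for so much. Going by these compounds, it also remains open whether an amine or a carboxylic acid at the end of this chain, or a longer chain carrying the 1,2-dihydroxyethyl group, would match or pass compound 3 at 21 nM.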